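A few compounds are considered here, and "the series" means these few. Any claim that something is new, unique, unknown or untested is made for them only; others in the source may bear on it.

The series rests on a shared core carrying an aminodimethoxyphenyl ketone joined through an unsaturated linker to a methylated indole. Compound 2 `COc1cc(C(=O)/C=C/c2cn(C)c3ccccc23)cc(N)c1OC` is the parent; in a functional assay on HeLa cells (Homo sapiens) for antiproliferative activity, read by MTT assay, with a stated time of 48 h (a higher number here means a weaker inhibitor, a lower number a stronger inhibitor), compound 2 gives 668 nM. Compound 1 `COc1ccc2c(/C=C/C(=O)c3cc(N)c(OC)c(OC)c3)cn(C)c2c1` adds a methoxy group to the indole side, the change being (methoxy in place of hydrogen on an aromatic carbon), and in this assay compound 1 gives 356 nM, a step of a 1.9-fold lower number from compound 2 to compound 1 (0.27 log units; within the scatter). Compound 3 `COc1cc(C(=O)/C=C/c2cn(C)c3ccccc23)cc([N+](=O)[O-])c1OC` differs from compound 2 by nitro in place of amino on an aromatic carbon; in this assay compound 3 gives 1960 nM, a step of a 2.9-fold higher number from compound 2 to compound 3 (0.47 log units; beyond the scatter).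

Compound 4 `COc1ccc2c(/C=C/C(=O)c3cc(OC)c(OC)c([N+](=O)[O-])c3)cn(C)c2c1` has not yet been measured in this assay. Its change from compound 3 is methoxy in place of hydrogen on an aromatic carbon, which is the same change as that from compound 2 to compound 1, their places matching word for word. Because the earlier step was a 1.9-fold lower number from compound 2 to compound 1 (0.27 log units; within the scatter), a step of similar size is expected for compound 4, namely a 1.8-fold lower number from compound 3 to compound 4 (0.25 log units; within the scatter). Compound 4 is therefore estimated at 1100 nM, with the expectation lying between 500 nM and 2500 nM.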

Compound 4, half-maximal inhibitory concentration: 951 nM
Compound 4: the middle estimate sits 1.2-fold (0.06 log units) above what was measured, within the range that was stated.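

Methoxy in place of hydrogen on an aromatic carbon carried over to the nitro-bearing core in this assay, with a 2.1-fold lower number from compound 3 to compound 4 (0.31 log units; beyond the scatter), and its two appearances agree: the same change on two cores in this assay, a 1.9-fold lower number (0.27 log units; within the scatter) from compound 2 to compound 1 and a 2.1-fold lower number (0.31 log units; beyond the scatter) from compound 3 to compound 4, 1.1-fold (0.04 log units) apart, within the scatter of two such steps. Nitro in place of amino on an aromatic carbon also kept its size on the methoxy-bearing core, with a 2.7-fold higher number from compound 1 to compound 4 (0.43 log units; beyond the scatter), and these two steps agree as well: the same change on two cores in this assay, a 2.9-fold higher number (0.47 log units; beyond the scatter) from compound 2 to compound 3 and a 2.7-fold higher number (0.43 log units; beyond the scatter) from compound 1 to compound 4, 1.1-fold (0.04 log units) apart, within the scatter of two such steps. The four compounds therefore show that each change transferred between these two cores with little difference in size, but they do not show why, nor that this would hold on any other core.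

The compounds shown leave open whether ethoxy or a fluorine atom at the same place would behave as methoxy does. They also leave open whether an acetamide or a carboxylic acid in place of the amino or nitro group would follow the same pattern.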